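A few compounds are considered here, and "the series" means these few. Any claim that something is new, unique, unknown or untested is made for them only; others in the source may bear on it.

In a functional assay on MCF7 cells (Homo sapiens) for inhibition, read by MTT assay, with a stated time of 48 h (a lower number here means a stronger inhibitor, a higher number a weaker inhibitor), compound 1 `Fc1ccccc1CSc1nnc(-c2ccncc2)n1-c1ccccc1` gives > 50000 nM, which is a limit of the assay. Compound 2 `Clc1cccc(CSc2nnc(-c3ccncc3)n2-c2ccccc2)c1` gives 10500 nM, and compound 3 `Fc1ccc(CSc2nnc(-c3ccncc3)n2-c2ccccc2)cc1` gives 21100 nM. Compound 3 thus sits level with its nearest measured neighbour, as a 2.0-fold higher number from compound 2 to compound 3 (0.30 log units; within the scatter) shows, and the other step to it is an at least 2.3-fold lower number from compound 1 to compound 3 (0.37 log units; beyond the scatter). Compound 4 `Brc1ccc(CSc2nnc(-c3ccncc3)n2-c2ccccc2)cc1` has bromo in place of fluoro on an aromatic carbon, para to a large group (bromo in place of fluoro on an aromatic carbon). For the measured compounds named here, no measured step makes this exchange. The closest one, a 2.0-fold higher number from compound 2 to compound 3 (0.30 log units; within the scatter), also changes the halogen and stays within the scatter, so no step beyond the scatter is expected, with a slight lean toward a lower number. The estimated step is a 1.4-fold lower number from compound 3 to compound 4 (0.15 log units; within the scatter). In this assay, the estimate for compound 4 is 15000 nM, with an expected range from 6000 nM to 35000 nM.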

Compound 4, half-maximal inhibitory concentration: 12600 nM
For compound 4 the middle estimate is 1.2-fold (0.08 log units) above the measured one; the range from low to high includes it.
By their numbers in this assay, from the lowest: compounds 2, 4 and 3 (each within the scatter of the next). At a limit, above all of these: compound 1.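

In this assay the exchange of fluoro for bromo on an aromatic carbon, para to a large group, gives a 1.7-fold lower number from compound 3 to compound 4 (0.22 log units; within the scatter) and so moves the number no further than the scatter. Compound 4 also stands level with the 3-chlorophenyl compound, with a 1.2-fold higher number from compound 2 to compound 4 (0.08 log units; within the scatter) on that pair. Compound 1 remains at a limit, so an at least 3.9-fold lower number from compound 1 to compound 4 (0.59 log units; beyond the scatter) gives only a bound: the limit of > 50000 nM in this assay, at which 1 of the 4 values shown sits.

The compounds shown leave open whether an amine or a carboxylic acid at this place on the ring would give a step beyond the scatter.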